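Working notes: from compound 2 to compound 4

This account rests on a few compounds, and the source may have more. Where it says the series, first, only, none or still open, it means among the compounds named here.

In an ADME assay on cells (Homo sapiens) for cytotoxicity, read by resazurin assay, with a stated time of 5 days (on this read-out lower numbers stand for higher toxicity in this test and higher numbers for lower toxicity in this test), the series gives limits only. Compound 1 `CCC1=C(C(=O)OCC2CCCCC2)C(c2cccc(O)c2)NC(=O)N1` stands at > 10000 nM as a limit of the test. Compound 2 `COc1ccc(-c2nc(CSCc3cccc(Cl)c3)nc3ccsc23)cn1` stands at > 50000 nM as a limit and has no exact number of its own. Compound 3 `COc1ccc(-c2nc(CCS(=O)(=O)c3cccc(Cl)c3)nc3ccsc23)cn1` stands at > 50000 nM as a limit too. Compound 4 `COc1ccc(-c2nc(C[S+]([O-])c3cccc(Cl)c3)nc3ccsc23)cn1` awaits measurement and shows a group of 9 heavy atoms (6 carbon, 1 oxygen, 1 sulfur, 1 chlorine; one six-membered aromatic ring of carbon only) in place of a group of 9 heavy atoms (7 carbon, 1 sulfur, 1 chlorine; one six-membered aromatic ring of carbon only), on a saturated chain carbon bound to an aromatic carbon relative to compound 2. Among the measured compounds shown here, no measured step is available for sizing this change, so no shift beyond the scatter is expected in this assay and another limit is the likely report. The expected move is a number no higher from compound 2 to compound 4 (the limit leaves the size open) and no more. For compound 4 the estimate is 50000 nM with an expected range from 25000 nM to 100000 nM in this test.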

Compound 4, half-maximal cytotoxic concentration: > 50000 nM
Compound 4: a limit, no number; the forecaster's own chance of this, stated with the estimate: 85%; the middle value lies on the limit itself.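

Among the compounds shown here, compound 2 and compound 4 both stand at a limit in this assay, so no step between them can be read. The compounds shown leave open where an exact value would fall for any of them.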